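Acylguanidine series: substituent change at the ethylsulfanyl position

The source may report more compounds than this note shows. Statements on the series, on what has been measured and on what is new or still open speak of the compounds shown alone.

Measured compounds in a functional assay for inhibition of sodium/hydrogen exchanger (Oryctolagus cuniculus); on this read-out higher numbers stand for weaker inhibition and lower numbers for stronger inhibition:
- compound 1, `CCN(CC)Cc1cc(Br)c(S(C)(=O)=O)cc1C(=O)N=C(N)N`: 9500 nM
- compound 2, `Cc1cc(-c2cc(Cl)cc(Cl)c2)c(S(C)(=O)=O)cc1C(=O)N=C(N)N`: 130 nM
- compound 3, `CCSc1cc(C)c(C(=O)N=C(N)N)cc1S(C)(=O)=O`: 5.9 nM

Compound 3 gives the lowest number of the three. Its step to compound 2 is beyond the scatter, and the values of compound 1 and compound 3 lie far apart as well, so compound 3 is the strongest inhibitor in this set. Compound 1 differs from the others in more than one place, so only its value is taken here.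

Compound 4, `Cc1cc(OC(C)(C)C)c(S(C)(=O)=O)cc1C(=O)N=C(N)N`, is the next step from compound 3. The change: tert-butoxy in place of ethylsulfanyl on an aromatic carbon. Among the compounds with values here, one measured step touches the same aromatic carbon: a 22-fold lower number from compound 2 to compound 3 (1.34 log units; beyond the scatter). It shows that the group on this carbon can move the read-out strongly, but it compares a ring-bearing group with a short chain, and no alkoxy group at this place has been measured. Tert-butoxy, like ethylsulfanyl, is a small uncharged group with one hydrogen-bond acceptor, so a step well short of the one from compound 2 to compound 3 is expected, most likely a modest weakening that may not exceed the scatter.

Compound 4 is therefore estimated at 15 nM in this assay, within 3 nM to 80 nM, which corresponds to an expected step of a 2.5-fold higher number from compound 3 to compound 4 (0.41 log units; beyond the scatter).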

Compound 4, half-maximal inhibitory concentration: 9.4 nM
Compound 4: the middle estimate sits 1.6-fold (0.20 log units) above what was measured, and the stated range covers the measured number.
By their numbers in this assay, from the lowest: compounds 3 and 4 (each within the scatter of the next); then compound 2; then compound 1.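

In this assay, the step is a 1.6-fold higher number from compound 3 to compound 4 (0.20 log units; within the scatter), so exchanging ethylsulfanyl, with 3 heavy atoms including sulfur, for tert-butoxy, with 5 heavy atoms including oxygen, gives no readable difference at this aromatic carbon. The second new step, a 14-fold lower number from compound 2 to compound 4 (1.14 log units; beyond the scatter), is large and points the same way as a 22-fold lower number from compound 2 to compound 3 (1.34 log units; beyond the scatter): both ring-free groups give much lower numbers than 3,5-dichlorophenyl, a pattern that rests on these three compounds alone. No supporting data bear on why the read-out responds in this way at this position.

The step between compound 3 and compound 4 changes the atom attached to the ring and the group's size together, so the compounds shown cannot separate the two; ethoxy or tert-butylsulfanyl at this carbon would address that question. On these data alone, it also remains open how this position responds to an amine such as dimethylamino, a carboxylic acid, a longer chain such as hexyl, or an unsubstituted phenyl, the last of which would show whether the higher number of compound 2 goes with the ring itself or with its two chlorines.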